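A few compounds are considered here, and "the series" means these few. Any claim that something is new, unique, unknown or untested is made for them only; others in the source may bear on it.

Among the compounds with values here, compound 1 `O=c1n(Cc2cn(Cc3cc4ccc(Cl)cc4nc3Cl)nn2)cnn1-c1ccccc1` stands second highest of the three numbers so far in an ADME assay on HEK293 cells (Homo sapiens) for cytotoxicity, read by MTT assay (on this read-out higher numbers stand for weaker inhibition and lower numbers for stronger inhibition), where compound 1 gives 869 ug/mL. Compound 3 `COc1ccc(-n2ncn(Cc3cn(Cc4cc5ccc(Cl)cc5nc4Cl)nn3)c2=O)cc1`, the nearest, gives 1470 ug/mL, and compound 2 `Cc1ccc2nc(Cl)c(Cn3cc(Cn4cnn(-c5ccccc5)c4=O)nn3)cc2c1`, the furthest, gives 478 ug/mL; both lie within the scatter of compound 1. Compound 4 `COc1ccc2cc(Cn3cc(Cn4cnn(-c5ccccc5)c4=O)nn3)c(Cl)nc2c1` differs from compound 1 by methoxy in place of chloro on an aromatic carbon. Within the data shown here, the one measured step that bears on this, a 1.7-fold higher number from compound 1 to compound 3 (0.23 log units; within the scatter), also brings in a methoxy on an aromatic carbon, though there in place of hydrogen, and stays within the scatter; compound 1 and compound 2 likewise lie within the scatter of each other. No step beyond the scatter in this assay is therefore expected for compound 4. Compound 4 is estimated at 900 ug/mL, between 450 ug/mL and 1800 ug/mL, an expected step of a 1.0-fold higher number from compound 1 to compound 4 (0.02 log units; within the scatter).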

Compound 4, half-maximal inhibitory concentration: 1010 ug/mL
Beside the measured number, compound 4's estimate is 1.1-fold (0.05 log units) below it; the measured number falls inside the stated range.
By their numbers in this assay, from the lowest: compounds 2, 1, 4 and 3 (each within the scatter of the next, the first and the last beyond it).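

In this assay, methoxy in place of chloro on this six-membered aromatic ring of carbon only gives a 1.2-fold higher number from compound 1 to compound 4 (0.07 log units; within the scatter), so this exchange at this position produces no step beyond the scatter. Within the data shown here, the earlier step, a 1.7-fold higher number from compound 1 to compound 3 (0.23 log units; within the scatter), placed methoxy in place of hydrogen at a different place, so this is the first reading for a replacement of chloro here. No measurement is available that would explain this result.

From the compounds shown here alone, whether an amine or a carboxylic acid at this position would give a step beyond the scatter remains open. A single exchange also cannot show how far this tolerance extends.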